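This account rests on a few compounds, and the source may have more. Where it says the series, first, only, none or still open, it means among the compounds named here.

Values in a functional assay on DU-145 cells (Homo sapiens) for inhibition, read by trypan blue exclusion, with a stated time of 96 h (on this read-out lower numbers stand for stronger inhibition of growth and higher numbers for weaker inhibition of growth), so far
- compound 1 `Cc1ccc(CS(=O)(=O)/C(=C/c2cccc(Cl)c2Cl)C(=O)c2ccc(Cl)cc2)cc1` gives 1000 nM
- compound 2 `CCOc1ccc(/C=C(\C(=O)c2ccc(Cl)cc2)S(=O)(=O)Cc2ccc(C)cc2)cc1OC` gives 10000 nM

Compound 2 holds the higher of the two numbers. Compound 3 `CCOc1ccc(/C=C(\C(=O)c2ccc(Cl)cc2)S(=O)(=O)Cc2ccccc2Cl)cc1OC` differs from it by 2-chlorophenyl in place of 4-methylphenyl on a saturated chain carbon bound to a sulfonyl sulfur and carries 2-chlorophenyl in place of 4-methylphenyl on a saturated chain carbon bound to a sulfonyl sulfur. For the measured compounds named here, the only measured step is a 10-fold higher number from compound 1 to compound 2 (1.00 log units; beyond the scatter) and it is beyond the scatter, but it concerns another group, so it gives no direct guide to this change. A small move toward a lower number in this assay is expected, since compound 2 at 10000 nM is the top of the range seen so far. a 1.7-fold lower number from compound 2 to compound 3 (0.22 log units; within the scatter) is the step expected here. Compound 3 is estimated at 6000 nM with a range of 2000 nM to 15000 nM on this read-out.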

Compound 3, concentration for 50% growth inhibition: 10000 nM
Estimate against measurement, compound 3: 1.7-fold (0.22 log units) below; the measured number falls inside the stated range.
By their numbers in this assay, from the lowest: compound 1; then compounds 2 and 3 (each within the scatter of the next).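

In this assay, 2-chlorophenyl in place of 4-methylphenyl on a saturated chain carbon bound to a sulfonyl sulfur gives no change at the digits printed from compound 2 to compound 3 (within the scatter). For the compounds shown here, this is the first reading at this position, and with 4-ethoxy-3-methoxyphenyl held constant, the two groups cannot be told apart. Nothing available explains this result.

From the compounds shown here alone, whether the same exchange would also leave the number unchanged with the 2,3-dichlorophenyl group of compound 1 stays open. Also open, going by these compounds, is what an amine or a carboxylic acid would do on the saturated chain carbon bound to the sulfonyl sulfur.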